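A few compounds are considered here, and "the series" means these few. Any claim that something is new, unique, unknown or untested is made for them only; others in the source may bear on it.

Measured compounds:
- compound 1 `C=C1CCC(c2csc(/C=C(\C)C(N)=O)c2)CC1`: 8470 nM
- compound 2 `C/C(=C\c1cc(-c2ccccc2)co1)C(N)=O`: 3340 nM
- compound 3 `C/C(=C\c1cc(-c2ccccc2)cs1)C(N)=O`: 2680 nM

All three share the same amide-bearing side chain and differ in the ring it sits on and in what that ring carries. In a functional assay on MCF7 cells (Homo sapiens) for cytotoxicity, read by CCK-8 assay, with a stated time of 24 h (on this read-out higher numbers stand for weaker inhibition and lower numbers for stronger inhibition), compound 3 gives 2680 nM, the lowest of the three numbers. Compound 2 gives 3340 nM, which lies within the usual scatter of compound 3, so the two cannot be told apart on these data. Compound 1 gives 8470 nM, a higher number that lies beyond the scatter.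

Compound 4 `C/C(=C\c1cc(-c2ccc(F)cc2)cs1)C(N)=O` is the next compound to be tested in this assay. Compared with compound 3, the change is fluoro in place of hydrogen on an aromatic carbon. For the measured compounds named here, no measured pair shows what this kind of change does here, so there is no direct guide. Such a small addition on a phenyl ring would be expected to move the number little, in either direction, and most likely not beyond the scatter. Compound 4 is therefore estimated at 2500 nM, with a range from 1000 nM to 6500 nM. This estimate means a step of a 1.1-fold lower number from compound 3 to compound 4 (0.03 log units; within the scatter) that is expected to stay within the scatter.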

Compound 4, half-maximal inhibitory concentration: 1440 nM
Compound 4: the middle estimate sits 1.7-fold (0.24 log units) above what was measured; the measured number falls inside the stated range.
By their numbers in this assay, from the lowest: compounds 4, 3 and 2 (each within the scatter of the next, the first and the last beyond it); then compound 1.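

For the compounds shown here, this pair is the first among the measured compounds that differ in one place only, so it gives the first direct reading of fluoro in place of hydrogen on an aromatic carbon, para to a large group. In this assay, the swap gives a 1.9-fold lower number from compound 3 to compound 4 (0.27 log units; within the scatter), so the two compounds cannot be told apart, and this position carries a fluoro without a step beyond the scatter. Nothing available explains this result in terms of cause.

Still open, from the compounds shown here alone, is whether an amine, a methoxy group or a carboxylic acid at this same place would give a step beyond the scatter, where the single fluorine atom does not. Going by these compounds, it is also open whether fluoro in place of hydrogen would give a similar step on the phenyl ring of compound 2.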